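Trading a side chain for cyano at the assay limit

The compounds below may be only part of what the source reports. "The series", "measured", "known", "first", "only" and "open" are said of these compounds alone.

Compound 1 `CC(=O)CCc1cc(C)c(Oc2cc(Nc3ccc(C#N)cc3)c(N)cc2C(F)(F)F)c(C)c1` is the starting point. In a physicochemical assay for lipophilicity, at pH 7.4 (on this read-out lower numbers stand for lower lipophilicity and higher numbers for higher lipophilicity), compound 1 gives > 5, which is a limit and not a number. That places compound 1 at the limit of > 5 in this assay, at which 2 of the 3 values shown sit. Compound 2 `Cc1cc(/C=C/C#N)cc(C)c1Oc1cc(Nc2ccc(C#N)cc2)c(N)cc1[N+](=O)[O-]` gives > 5, again a limit. Compound 3 `COC(=O)c1cc(N)c(Nc2ccc(C#N)cc2)cc1Oc1c(C)cc(/C=C/C#N)cc1C` gives a true number, 4.15.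

The next structure is compound 4 `Cc1cc(C#N)cc(C)c1Oc1cc(Nc2ccc(C#N)cc2)c(N)cc1C(F)(F)F`, reached from compound 1 by cyano in place of 2-acetylethyl on an aromatic carbon, with cyano in place of 2-acetylethyl on an aromatic carbon. Among the measured compounds shown here, no measured step makes this same swap. For the measured compounds named here, the only guide is a different one, a number at least 0.85 log units lower from compound 2 to compound 3 (beyond the scatter), with methoxycarbonyl in place of nitro on an aromatic carbon. It shows that changing one group can bring a compound down from the limit to a number. Taking that step and compound 3 at 4.15 as rough guides, a modest fall in this assay is expected, beyond the scatter. The expected change is a number at least 0.40 log units lower from compound 1 to compound 4 (beyond the scatter). For compound 4 the estimated value is 4.6, with an expected range of 4 to 5.2.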

Compound 4, partition coefficient: > 5
Compound 4: only a limit was reported; the forecaster's own chance of this, stated with the estimate: 25%; middle value at least 0.40 log units away from the limit.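

In this assay compound 4 gives > 5, which is a limit and not a number. Among the compounds shown here, compound 1 also gives only a limit, so no step between compound 1 and compound 4 can be read: the limit of > 5 in this assay, at which 3 of the 4 values shown sit. From the compounds shown here alone, how far cyano in place of 2-acetylethyl moves the value stays open.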